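The compounds below may be only part of what the source reports. "The series", "measured", "known", "first", "only" and "open" are said of these compounds alone.

In a functional assay on HepG2 cells (Homo sapiens) for cytotoxicity, read by spectrophotometry, with a stated time of 72 h (on this read-out higher numbers stand for weaker inhibition and lower numbers for stronger inhibition), compound 1 `COc1ccc(-c2cccc(=O)n2-c2cc(OC)c(OC)c(OC)c2)cc1OCc1ccccc1` gives 269 nM and compound 3 `COc1cc(-n2c(-c3cccc(F)c3)cccc2=O)cc(OC)c1OC` gives 159 nM, two values within the scatter of each other. Compound 2 `COc1ccc(-c2cccc(=O)n2-c2cc(OC)c(OC)c(OC)c2)cc1O` reads < 10 nM, which is a limit of the assay. Compound 4 `COc1cc(-n2c(-c3cccc(O)c3)cccc2=O)cc(OC)c1OC` carries hydroxy in place of fluoro on an aromatic carbon, meta to a large group (hydroxy in place of fluoro on an aromatic carbon). Two large steps bear on this: an at least 26-fold lower number from compound 1 to compound 2 (1.42 log units; beyond the scatter), with hydrogen in place of benzyl, and an at least 15-fold higher number from compound 2 to compound 3 (1.20 log units; beyond the scatter), with 3-fluorophenyl in place of 3-hydroxy-4-methoxyphenyl. Compound 4 lacks the methoxy of compound 2, so in this assay only part of the second step is expected back, as a lower number. The expected move is a 3.2-fold lower number from compound 3 to compound 4 (0.50 log units; beyond the scatter). For compound 4 the estimate is 50 nM, with an expected range of 10 nM to 250 nM.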

Compound 4, half-maximal inhibitory concentration: 34 nM
The estimate for compound 4 lay 1.5-fold (0.17 log units) above the measured number, and the stated range covers the measured number.
By their numbers in this assay, from the lowest: compound 4; then compounds 3 and 1 (each within the scatter of the next). At a limit, below all of these: compound 2.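

Hydroxy in place of fluoro, on an aromatic carbon meta to a large group, gives a 4.7-fold lower number from compound 3 to compound 4 (0.67 log units; beyond the scatter) in this assay, so the hydroxy counts on its own, whereas the earlier step changed it together with the methoxy. The methoxy also counts, since hydrogen in place of methoxy gives an at least 3.4-fold higher number from compound 2 to compound 4 (0.53 log units; beyond the scatter). The value of compound 2 is a limit, so this second step has no full size: the limit of < 10 nM in this assay, at which 1 of the 4 values shown sits.

Open, from the compounds shown here alone, is whether an amine or a carboxylic acid at this place would give a number as low as hydroxy does.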